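Benzimidazolylmethyl piperazines at the D4 receptor: a methylpyridyl variant

The source may report more compounds than this note shows. Statements on the series, on what has been measured and on what is new or still open speak of the compounds shown alone.

Compound 1 `N#Cc1cccnc1N1CCN(Cc2nc3ccccc3[nH]2)CC1`: 13.9 nM
Compound 2 `O=[N+]([O-])c1ccccc1N1CCN(Cc2nc3ccccc3[nH]2)CC1`: 3.9 nM
Compound 3 `CS(=O)(=O)c1cccnc1N1CCN(Cc2nc3ccccc3[nH]2)CC1`: 136 nM

Of the compounds shown here, three sharing a common core have been measured in an assay on HEK293 cells with D(4) dopamine receptor (Homo sapiens) as the target, read by FLIPR; a higher number here means that more compound is needed for the effect, a lower number that less compound is needed. Compound 1 stands second highest of the three numbers: compound 2 gives a lower number, and compound 3 gives a higher one. Among the measured compounds shown here, the single one-place step among them, a 9.8-fold higher number from compound 1 to compound 3 (0.99 log units; beyond the scatter), is a modest move toward weaker activity.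

Compound 4 `Cc1cccc(N2CCN(Cc3nc4ccccc4[nH]3)CC2)n1` has not yet been measured. It differs from compound 1 in one place: 6-methylpyridin-2-yl in place of 3-cyanopyridin-2-yl on an amine nitrogen in a ring. The change removes the cyano group entirely and adds a methyl group on a different ring carbon, so it is not a direct match to any step seen so far. For the measured compounds named here, the only step that bears on it at all is the one from compound 1 to compound 3, where replacing the cyano group with methylsulfonyl raised the number by a modest amount; that step shows that the cyano position is not indifferent, but it does not show what its removal does. On this thin basis a moderate rise beyond the scatter is expected, a 2.5-fold higher number from compound 1 to compound 4 (0.40 log units; beyond the scatter). Compound 4 is therefore estimated at 35 nM, with a plausible range from 9 nM to 140 nM in this assay.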

Compound 4, half-maximal effective concentration: 36.2 nM
Beside the measured number, compound 4's estimate is 1.0-fold (0.01 log units) below it; low and high end bracket the measured number.
By their numbers in this assay, from the lowest: compound 2; then compound 1; then compound 4; then compound 3.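

In this assay, the new step gives a 2.6-fold higher number from compound 1 to compound 4 (0.42 log units; beyond the scatter), which shows that the nitrile is not required for a measurable effect when 6-methylpyridin-2-yl takes the place of 3-cyanopyridin-2-yl on the amine nitrogen in the ring. Both steps shown from compound 1 now lead to a higher number, and the printed values place compound 4 well short of compound 3, so this replacement costs less than the methylsulfonyl change did. The step makes two changes at once, however. The nitrile leaves and a methyl group enters on a different ring carbon, and no measurement shown here accounts for the rise.

The compounds shown leave open how much of the step belongs to the lost nitrile and how much to the added methyl, a question that a plain pyridin-2-yl group on the same nitrogen would address directly. They also leave open whether a methoxy group or an amine in place of the methyl would bring the number back toward that of compound 1 or push it higher.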